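This account rests on a few compounds, and the source may have more. Where it says the series, first, only, none or still open, it means among the compounds named here.

Measured compounds:
compound 1 `O=C(Nc1ccc(F)cc1)c1n[nH]cc1NC(=O)c1c(F)ccc(-c2cccc(CO)c2)c1F`: "not determined" (no result reported)
compound 2 `O=C(Nc1ccc(F)cc1)c1n[nH]cc1NC(=O)c1c(F)ccc(-c2cccc(O)c2)c1F`: "not determined" (no result reported)
compound 3 `NC(=O)c1cccc(-c2ccc(F)c(C(=O)Nc3c[nH]nc3C(=O)Nc3ccc(F)cc3)c2F)c1`: 1990 nM

Three compounds of this series carry the same core. For compound 1 and compound 2 no result was reported. Among the compounds with values here, compound 3 is therefore the only one with a number: in a functional assay on A2058 cells (Homo sapiens) for antiproliferative activity, read by luminescence and CellTiter-Glo, with a stated time of 96 h (on this read-out higher numbers stand for weaker inhibition and lower numbers for stronger inhibition), compound 3 gives 1990 nM, a figure that places it among weak inhibitors, with nothing else in the set to compare it against.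

Compound 4 `O=C(Nc1ccc(F)cc1)c1n[nH]cc1NC(=O)c1c(F)ccc(-c2ccncc2)c1F` has not yet been measured. It differs from compound 3 in one place: pyridin-4-yl in place of 3-carbamoylphenyl on an aromatic carbon. The substituent that enters is smaller than the one that leaves and carries no hydrogen-bond donor. Within the data shown here, no measured pair in this set shows a comparable change, so there is no step to lean on.

The expected step is a 1.5-fold higher number from compound 3 to compound 4 (0.18 log units; within the scatter), that is a shift toward weaker inhibition that may well stay within the scatter of this assay. Compound 4 is accordingly estimated at 3000 nM, with a range from 700 nM to 12000 nM.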

Compound 4, half-maximal inhibitory concentration: 2940 nM
The estimate for compound 4 lay 1.0-fold (0.01 log units) above the measured number; low and high end bracket the measured number.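

In this assay, placing pyridin-4-yl instead of 3-carbamoylphenyl on this aromatic carbon, ortho to a fluoro group, gives a 1.5-fold higher number from compound 3 to compound 4 (0.17 log units; within the scatter) and so does not separate the two groups. In this single pair, a substituent with fewer heavy atoms and no hydrogen-bond donor reads the same as the larger one that carries a hydrogen-bond donor, so that donor is not shown to matter for the read-out here. Nothing measured on these compounds accounts for this result.

The steps involving compound 1 and compound 2 cannot be read, as neither compound has a number. Going by these compounds, whether a carboxylic acid, an aminomethyl group or a morpholine ring at this position would move the number beyond the scatter remains open.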